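A few compounds are considered here, and "the series" means these few. Any claim that something is new, unique, unknown or untested is made for them only; others in the source may bear on it.

In an ADME assay on HepG2 cells (Homo sapiens) for cytotoxicity (on this read-out higher numbers stand for lower toxicity in this test and lower numbers for higher toxicity in this test), compound 1 (`CC(F)(F)c1cccc(N2C(=O)CN(c3cccc(C(F)(F)F)c3)CC2C(=O)NC2CCCC2)c1`) gives 9000 nM as a measured number. Compound 2 (`O=C(NCC1CC1)C1CN(c2ccccc2)CC(=O)N1c1ccc2ccsc2c1`) stands at > 50000 nM on the same read-out, and this is a limit and not a number. Compound 3 (`O=C(Nc1cccnc1)C1CN(c2ccccc2)CC(=O)N1c1ccc2ccsc2c1`) is compound 2 with pyridin-3-yl in place of cyclopropylmethyl on an amide-type nitrogen. Among the measured compounds shown here, no measured pair shows what such a swap does, so the forecast is a loose one. For the measured compounds named here, compound 1 at 9000 nM is the only actual number available. A reading under the limit of compound 2 remains possible for compound 3. In this assay the expected change is small, either no step beyond the scatter or a slight move toward higher toxicity, and an at least 1.2-fold lower number from compound 2 to compound 3 (0.09 log units; that floor lies within the scatter) is the estimated step in figures. The estimate for compound 3 is 40000 nM (expected range 15000 nM to 90000 nM).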

Compound 3, half-maximal cytotoxic concentration: > 50000 nM
Compound 3: a limit, no number; the forecaster's own chance of this, stated with the estimate: 55%; middle value at least 1.2-fold (0.09 log units) from the limit.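

No step can be read from compound 2 to compound 3 in this assay, because both results stop at a limit and give no number: the limit of > 50000 nM in this assay, at which 2 of the 3 values shown sit.

On these data alone, what stays open is how far each compound lies past that limit, and whether pyridin-3-yl in place of cyclopropylmethyl changes the read-out at all.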